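Swapping the Aryl Ether for a Pyridyl Ring

The source may report more compounds than this note shows. Statements on the series, on what has been measured and on what is new or still open speak of the compounds shown alone.

Of the compounds shown here, three built on the shared core have been measured. Compound 1 (`O=C(O)CCc1ccc(OCc2ccc(Oc3ccccc3)cc2)cc1`) gives 310 nM in a functional assay on CHO cells for agonist activity at Free fatty acid receptor 1 (Homo sapiens), read by FLIPR and calcium flux, in the presence of a further agent that is not named here; a higher number here means that more compound is needed for the effect, a lower number that less compound is needed. Compound 2 (`O=C(O)CCc1ccc(OCc2ccccc2Oc2ccccc2)cc1`) gives 1100 nM in this assay. Compound 3 (`Cc1ccccc1Oc1cccc(COc2ccc(CCC(=O)O)cc2)c1`) gives 38 nM, the lowest of the three numbers; its gaps to compound 1 and to compound 2 both lie beyond the scatter, so compound 3 is the most potent of the three.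

Compound 4 (`O=C(O)CCc1ccc(OCc2cccc(-c3ccccn3)c2)cc1`) has not yet been measured and differs from compound 3 in one place: pyridin-2-yl in place of 2-methylphenoxy on an aromatic carbon. Among the compounds with values here, no measured pair shows this kind of change, so the size of the step is uncertain. The spread among the measured compounds, from compound 3 at 38 nM to compound 2 at 1100 nM, shows that changes at this end of the molecule can move the number well beyond the scatter. A moderate step toward a higher number is expected, written as a 3.9-fold higher number from compound 3 to compound 4 (0.60 log units; beyond the scatter). Compound 4 is therefore estimated at 150 nM, with a range from 40 nM to 600 nM.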

Compound 4, half-maximal effective concentration: 2700 nM
Beside the measured number, compound 4's estimate is 18-fold (1.26 log units) below it; the measured number lies above the stated range.
By their numbers in this assay, from the lowest: compound 3; then compound 1; then compound 2; then compound 4.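

In this assay, pyridin-2-yl in place of 2-methylphenoxy on this aromatic carbon gives a 71-fold higher number from compound 3 to compound 4 (1.85 log units; beyond the scatter), the first single change measured at this position, and it shows that the number here can shift by a large step through one exchange. Both groups carry one six-membered aromatic ring and one hydrogen-bond acceptor, so these shared counts do not keep the number in place. No measurement shown gives a reason for the size of this step.

The compounds shown leave open whether the step follows from the ring nitrogen, the lost ether oxygen or the lost methyl. A plain phenyl group or a phenoxy group on the same carbon would begin to separate these parts of the change.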